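Benzothiophene in place of pyridine on the shared core

The source may hold more compounds than are shown below. What is called first, only, known or untested is meant among the compounds shown, and "the series" means these compounds.

Among the compounds with values here, compound 2 `Nc1ccc(S(=O)(=O)N2CCN(c3ncc(C(O)(C(F)(F)F)C(F)(F)F)cc3-c3cccnc3)CC2)cn1` stands lowest of the two numbers so far in an ADME assay (liver) for metabolic stability, with Liver microsome (Rattus norvegicus) as the target, using microsomes and NADPH, with a stated time of 30 min, tested at 1 uM; on this read-out higher numbers stand for fast clearance and lower numbers for slow clearance: compound 2 gives 20 mL.min-1.g-1, while compound 1 `Nc1ccc(S(=O)(=O)N2CCN(c3ncc(C(O)(C(F)(F)F)C(F)(F)F)cc3C#CCCO)CC2)cn1` gives 68 mL.min-1.g-1. Within the data shown here, the one step measured at the same position, a 3.4-fold lower number from compound 1 to compound 2 (0.53 log units; beyond the scatter), shows that swapping the group on this aromatic carbon moves the read-out beyond the scatter.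

Compound 3 `Nc1ccc(S(=O)(=O)N2CCN(c3ncc(C(O)(C(F)(F)F)C(F)(F)F)cc3-c3cc4ccccc4s3)CC2)cn1` differs from compound 2 only there: 1-benzothiophen-2-yl in place of pyridin-3-yl on an aromatic carbon. No measured pair shows this particular swap, so the step from compound 1 to compound 2 bears on it only in that it marks the position as sensitive; the direction for a benzothiophenyl group in place of a pyridinyl group is not shown by any step here.

With nothing shown for this group, the expectation for compound 3 is a number above that of compound 2, estimated as a 2.3-fold higher number from compound 2 to compound 3 (0.35 log units; beyond the scatter). Compound 3 is therefore expected at about 45 mL.min-1.g-1 in this assay, within a range of 20 mL.min-1.g-1 to 110 mL.min-1.g-1, the lower end reaching back to where compound 2 stands.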

Compound 3, intrinsic clearance in microsomes: 315 mL.min-1.g-1
Beside the measured number, compound 3's estimate is 7.0-fold (0.85 log units) below it, outside the stated range (above it).
By their numbers in this assay, from the lowest: compound 2; then compound 1; then compound 3.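

In this assay this aromatic carbon proves far more sensitive than the first pair suggested: 1-benzothiophen-2-yl in place of pyridin-3-yl gives a 16-fold higher number from compound 2 to compound 3 (1.20 log units; beyond the scatter) as a large step, against the modest 3.4-fold lower number from compound 1 to compound 2 (0.53 log units; beyond the scatter) in the earlier comparison. The same group also stands above the 4-hydroxybut-1-yn-1-yl group, with a 4.6-fold higher number from compound 1 to compound 3 (0.67 log units; beyond the scatter) on the intrinsic clearance read-out, so the two groups with aromatic rings sit at opposite ends of the three and an aromatic ring at this place does not by itself go with a low number. Nothing available accounts for the size of these steps.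

Still open, going by these compounds, is whether the rise follows the six-membered carbon ring of 1-benzothiophen-2-yl or its sulfur-bearing five-membered ring, a question that thiophen-2-yl, phenyl or benzofuran-2-yl on this carbon would address. Also open, on these data alone, is whether an amine or a carboxylic acid placed on the 1-benzothiophen-2-yl group would bring the number back towards that of compound 2.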